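This account rests on a few compounds, and the source may have more. Where it says the series, first, only, none or still open, it means among the compounds named here.

Measured compounds:
- compound 1 `O=S(=O)(Nc1ccc(-c2nc3cc(NS(=O)(=O)c4ccccc4O)ccc3o2)cc1)c1ccccc1O` gives 18000 nM
- compound 2 `Cc1ccccc1S(=O)(=O)Nc1ccc2oc(-c3ccccc3)nc2c1` gives > 100000 nM
- compound 3 `O=S(=O)(Nc1ccc(-c2nc3ccccc3o2)cc1)c1cccc(O)c1` gives 62000 nM

All three were tested in an assay on cells for inhibition of HSP60/HSP10 (Homo sapiens), with a stated time of 60 min; a higher number here means a weaker inhibitor, a lower number a stronger inhibitor. Compound 1 gives 18000 nM and compound 3 gives 62000 nM, so both are weak inhibitors, with compound 1 the lower of the two. For compound 2 the result of > 100000 nM is a limit of the assay, not a number: the compound inhibited too little for a value to be read. That limit is described as the limit of > 100000 nM in this assay, at which 1 of the 3 values shown sits. Compound 2 therefore stands at the weak end of everything measured here, with no number to compare directly.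

Compound 4 `O=S(=O)(Nc1ccc2oc(-c3ccccc3)nc2c1)c1ccc(Cl)cc1` has not yet been measured. It differs from compound 2 in one place: 4-chlorophenyl in place of 2-methylphenyl on a sulfonyl sulfur. The shared core and the sulfonamide link are unchanged. Among the measured compounds shown here, no step between two measured compounds of this kind exists here, so there is nothing to show how swapping one ring on the sulfonyl sulfur for another moves the result. Given that compound 2 reached only the limit, compound 4 is expected to stay weak, and the expected step of an at least 1.2-fold lower number from compound 2 to compound 4 (0.09 log units; that floor lies within the scatter) is none beyond the scatter. Compound 4 is estimated to give 80000 nM, somewhere between 20000 nM and 300000 nM.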

Compound 4, half-maximal inhibitory concentration: > 100000 nM
Compound 4: a limit, no number; the forecaster's own chance of this, stated with the estimate: 55%; middle value at least 1.2-fold (0.09 log units) from the limit.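

In this assay compound 4 gives > 100000 nM as a limit of the assay, not a number. Compound 2 also stands at a limit, so no step can be read between compound 2 and compound 4: the limit of > 100000 nM in this assay, at which 2 of the 4 values shown sit.

The compounds shown leave open how 4-chlorophenyl and 2-methylphenyl on the sulfonyl sulfur truly compare.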